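This account rests on a few compounds, and the source may have more. Where it says the series, first, only, none or still open, it means among the compounds named here.

Of the compounds shown here, three built on one shared core have been tested in a functional assay on HepG2 cells (Homo sapiens) for inhibition, read by MTT assay; on this read-out higher numbers stand for weaker inhibition and lower numbers for stronger inhibition. Compound 1 `COc1cc2ncnc(Nc3ccc(NC(=O)c4cccc(C)c4)cc3)c2cc1OC` carries a (3-methylphenyl)carbonyl group and gives 7500 nM, the lowest of the three numbers. Compound 2 `COc1cc2ncnc(Nc3ccc(NC(=O)c4ccc(C)cc4)cc3)c2cc1OC`, with 4-methylphenyl in place of 3-methylphenyl on the carbonyl carbon, gives 25000 nM; the step of a 3.3-fold higher number from compound 1 to compound 2 (0.52 log units; beyond the scatter) is modest yet beyond the scatter. Compound 3 `COc1cc2ncnc(Nc3ccc(NC(=O)c4ccccc4F)cc3)c2cc1OC`, with 2-fluorophenyl on the carbonyl carbon, gives 13000 nM, and the step of a 1.7-fold higher number from compound 1 to compound 3 (0.24 log units; within the scatter) stays within the scatter.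

Compound 4 `COc1cc2ncnc(Nc3ccc(NC(=O)c4cccc(F)c4)cc3)c2cc1OC` has not yet been measured. It differs from compound 1 by fluoro in place of methyl on an aromatic carbon, a single-atom exchange on an aromatic carbon of a six-membered aromatic ring of carbon only. Within the data shown here, no measured step makes exactly this exchange. The two steps that touch this ring point in different directions: relocating the methyl raised the number, while a fluoro on this ring left the number where it was. Compound 4 is therefore expected to give 9000 nM, with a range from 4000 nM to 22000 nM. The expected step of a 1.2-fold higher number from compound 1 to compound 4 (0.08 log units; within the scatter) is estimated to stay within the scatter.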

Compound 4, half-maximal inhibitory concentration: 8200 nM
Estimate against measurement, compound 4: 1.1-fold (0.04 log units) above, within the range that was stated.
By their numbers in this assay, from the lowest: compounds 1, 4, 3 and 2 (each within the scatter of the next, the first and the last beyond it).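

In this assay, fluoro and methyl on this aromatic carbon cannot be told apart, since exchanging them gives a 1.1-fold higher number from compound 1 to compound 4 (0.04 log units; within the scatter), and the 3-methylphenyl group of compound 1 can therefore be replaced by 3-fluorophenyl with no readable effect. The fluoro's place on the ring also makes no readable difference, with 3-fluorophenyl in place of 2-fluorophenyl giving a 1.6-fold lower number from compound 3 to compound 4 (0.20 log units; within the scatter), whereas 3-fluorophenyl in place of 4-methylphenyl gives a 3.0-fold lower number from compound 2 to compound 4 (0.48 log units; beyond the scatter), so compound 2 stands apart from compound 4 as it does from compound 1, though not from compound 3. No measurement shown here offers an explanation for these results.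

Still open, as far as these compounds go, is whether a 4-fluorophenyl group would match compound 2 or compound 4, which would show whether the step to compound 2 follows the ring place or the methyl. Also open, from the compounds shown here alone, is how a methoxy, an amine or a carboxylic acid would fare on this same aromatic carbon.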